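Taking the chloro group off compound 1

The compounds below may be only part of what the source reports. "The series", "measured", "known", "first", "only" and "open" are said of these compounds alone.

Compound 1 `O=C(CCCCCCn1cc(Nc2ncc(Cl)c(Nc3cccc(Cl)c3)n2)cn1)NO` gives 130 nM
Compound 2 `COc1ccc(Nc2nc(Nc3cnn(CCCCCCC(=O)NO)c3)ncc2Cl)cc1` gives 170 nM
Compound 3 `O=C(CCCCCCn1cc(Nc2ncc(Cl)c(Nc3ccc(F)cc3)n2)cn1)NO` gives 220 nM
Compound 4 `O=C(CCCCCCn1cc(Nc2ncc(Cl)c(Nc3ccccc3)n2)cn1)NO` is still unmeasured

All three values come from a functional assay on MOLT-4 cells (Homo sapiens) for antiproliferative activity, read by MTT assay, with a stated time of 48 h; on this read-out lower numbers stand for stronger inhibition and higher numbers for weaker inhibition. Compound 1 cannot be separated from the other two, since every gap among the three lies within the scatter, including a 1.3-fold higher number from compound 2 to compound 3 (0.11 log units; within the scatter).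

Compound 4 differs from compound 1 in one place: hydrogen in place of chloro on an aromatic carbon. Put simply, hydrogen sits in place of chloro on an aromatic carbon, so 3-chlorophenyl becomes phenyl.

Among the compounds with values here, no measured step removes a group from this ring and leaves it bare, so the evidence is indirect. The nearest guides are the two swaps of the same ring, a 1.3-fold higher number from compound 1 to compound 2 (0.12 log units; within the scatter) and a 1.7-fold higher number from compound 1 to compound 3 (0.23 log units; within the scatter). Neither left the scatter, so no step beyond the scatter is expected in this assay, and no direction is firmly indicated. The estimated step is a 1.5-fold higher number from compound 1 to compound 4 (0.19 log units; within the scatter). For compound 4 the expected value is 200 nM, with an estimated range of 100 nM to 400 nM.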

Compound 4, half-maximal inhibitory concentration: 160 nM
Compound 4: the middle estimate sits 1.3-fold (0.10 log units) above what was measured, within the range that was stated.
By their numbers in this assay, from the lowest: compounds 1, 4, 2 and 3 (each within the scatter of the next).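

Compound 4 gives this position a bare phenyl ring as a reference point, which the earlier swaps of one group for another could not provide. In this assay, removing the chloro group gives a 1.2-fold higher number from compound 1 to compound 4 (0.09 log units; within the scatter) and so does not separate chloro from hydrogen at this position. The same holds for the other two groups, with a 1.4-fold lower number from compound 3 to compound 4 (0.14 log units; within the scatter) for fluoro and a 1.1-fold lower number from compound 2 to compound 4 (0.03 log units; within the scatter) for methoxy, so on these compounds this ring shows no measurable preference among hydrogen, chloro, fluoro and methoxy, and no measurement here explains that result.

From the compounds shown here alone, it remains open whether an amine or a carboxylic acid on this ring would produce a step beyond the scatter. The compounds shown also leave open whether a change outside this ring, such as a longer chain, would do so.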